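Bromo to Iodo on the Aryl Urea: Ortho and Para

The compounds below may be only part of what the source reports. "The series", "measured", "known", "first", "only" and "open" are said of these compounds alone.

Measured compounds:
compound 1, `C[C@@H](NC(=O)Nc1ccccc1Br)c1ccccc1`, 100%
compound 2, `C[C@@H](NC(=O)Nc1ccc(Br)cc1)c1ccccc1`, 95%
compound 3, `C[C@@H](NC(=O)Nc1ccccc1I)c1ccccc1`, 100%

The study collects three measured ureas and one that has not yet been measured. In an ADME assay on the whole organism with Oryza sativa as the target, tested at 1 uM (a higher number here means a weaker effect of the compound at the concentration tested, a lower number a stronger effect), compound 1 gives 100%, compound 2 gives 95% and compound 3 gives 100%. Compound 3 arises from compound 1 by iodo in place of bromo on an aromatic carbon, and the measured step reads no change at the digits printed from compound 1 to compound 3 (within the scatter). Compound 2 has the same atoms as compound 1 but joined differently; the difference between the two cores is not broken down here.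

Compound 4, `C[C@@H](NC(=O)Nc1ccc(I)cc1)c1ccccc1`, has not been measured. It arises from compound 2 by iodo in place of bromo on an aromatic carbon. This is the same kind of change as that from compound 1 to compound 3, though not the same change: in the one case the iodo enters ortho to a large group, in the other para to a large group. Among the four compounds this exchange occurs twice.

For compound 4 in this assay the step expected is no change at the digits printed from compound 2 to compound 4 (within the scatter), resting on compound 1 and compound 3, whose step no change at the digits printed from compound 1 to compound 3 (within the scatter) gave no change, so that the exchange is expected to leave the value of compound 2 essentially where it stands. The estimated value for compound 4 is therefore 95%, with a range from 85% to 100%.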

Compound 4, a percentage reported as activity, at one concentration (the size of the read-out at that concentration, not a potency): 91%
The estimate for compound 4 lay 4 percentage points above the measured number; the range from low to high includes it.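

In this assay, iodo in place of bromo on an aromatic carbon, para to a large group, gives a number 4 percentage points lower from compound 2 to compound 4 (within the scatter). Set beside the earlier step, this exchange carries from one core to the other without a difference that can be told apart from the scatter: the same change on two cores in this assay, no change at the digits printed (within the scatter) from compound 1 to compound 3 and a number 4 percentage points lower (within the scatter) from compound 2 to compound 4, 4 percentage points apart, within the scatter of two such steps

Among the compounds shown here, what transfers, however, is a step too small to be read on either core, so the agreement shows only that the exchange of these two halogens leaves both pairs within the scatter at the single concentration tested, and it gives no size for the exchange that could be applied elsewhere. It does not show that the same would hold on a core with a clearly stronger effect in this assay, and two pairs set no rule for the wider series.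

The compounds shown leave open whether anything other than a heavy halogen at these places would move the read-out beyond the scatter, for instance a fluoro, a nitrile, an amine or a carboxylic acid. They also leave open what a change elsewhere on the shared core, such as a longer chain in place of the methyl group, would do.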